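One Methoxy Added to Compound 3

A few compounds are considered here, and "the series" means these few. Any claim that something is new, unique, unknown or untested is made for them only; others in the source may bear on it.

In a functional assay on HCT-8 cells (Homo sapiens) for antiproliferative activity, read by MTT assay, with a stated time of 48 h (on this read-out higher numbers stand for weaker inhibition and lower numbers for stronger inhibition), compound 3 (`COc1cc(C(=O)/C=C/c2cn(C)c3ccccc23)cc([N+](=O)[O-])c1OC`) gives 1660 nM. Compound 1 (`COc1ccc2c(/C=C/C(=O)c3cc(OC)c(OC)c([N+](=O)[O-])c3)c[nH]c2c1`) gives 982 nM, which lies within the scatter of the reading for compound 3. Compound 2 (`COc1ccc2c(/C=C/C(=O)c3cc(OC)c(OC)c(SC)c3)cn(C)c2c1`) gives 157 nM, a much lower number that lies well beyond the scatter from compound 3.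

Compound 4 (`COc1ccc2c(/C=C/C(=O)c3cc(OC)c(OC)c([N+](=O)[O-])c3)cn(C)c2c1`) is compound 3 with methoxy in place of hydrogen on an aromatic carbon. No two measured compounds differ by this change alone, so its size has not been shown directly. The same methoxy is present in compound 1, at 982 nM, and in compound 2, at 157 nM, but both differ from compound 3 in other ways as well. These two readings suggest a moderate move toward stronger inhibition rather than none, though with wide uncertainty. In this assay, the expected step is a 3.3-fold lower number from compound 3 to compound 4 (0.52 log units; beyond the scatter). For compound 4, the estimated value is 500 nM, with an expected range of 130 nM to 1700 nM.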

Compound 4, half-maximal inhibitory concentration: 753 nM
Estimate against measurement, compound 4: 1.5-fold (0.18 log units) below; measured number inside the range.
By their numbers in this assay, from the lowest: compound 2; then compounds 4, 1 and 3 (each within the scatter of the next, the first and the last beyond it).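

In this assay the methoxy change can now be read on its own: the step is a 2.2-fold lower number from compound 3 to compound 4 (0.34 log units; beyond the scatter) and counts as modest, for methoxy in place of hydrogen on an aromatic carbon of the fused system. With that methoxy present, nitro in place of methylsulfanyl gives a 4.8-fold higher number from compound 2 to compound 4 (0.68 log units; beyond the scatter) and so is also a modest step, while methyl in place of hydrogen on the aromatic nitrogen gives a 1.3-fold lower number from compound 1 to compound 4 (0.12 log units; within the scatter) and shows no change beyond the scatter. Nothing available explains the size of these steps.

The compounds shown leave open how an ethoxy group, a fluorine atom or an amine would read on the same aromatic carbon. They also leave open whether the methoxy step would keep its size with methylsulfanyl in place of nitro.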